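The compounds below may be only part of what the source reports. "The series", "measured", "known", "first", "only" and "open" are said of these compounds alone.

Measured so far in a functional assay on BJAB cells (Homo sapiens) for antiproliferative activity, with a stated time of 4 days; on this read-out higher numbers stand for an effect only at larger amounts of compound and lower numbers for an effect already at smaller amounts:

Compound 1 `Cc1nn(-c2nc(-c3ccc(Cl)c(Cl)c3)c(SC(C)C)s2)c(C(=O)O)c1-c1cncnc1`: 22000 nM
Compound 2 `Cc1nn(-c2nc(-c3ccc(Cl)c(Cl)c3)c(SC(C)C)s2)c(C(=O)O)c1-c1cccc(F)c1`: 900 nM
Compound 3 `COc1cc(Cl)cc(-c2c(C)nn(-c3nc(-c4ccc(Cl)c(Cl)c4)c(SC(C)C)s3)c2C(=O)O)c1`: 760 nM

Compound 3 has the lowest of the three numbers in this assay. Against compound 2 the gap is a 1.2-fold lower number from compound 2 to compound 3 (0.07 log units; within the scatter), which does not separate the two. Against compound 1 the gap is a 29-fold lower number from compound 1 to compound 3 (1.46 log units; beyond the scatter).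

Compound 4 `Cc1nn(-c2nc(-c3ccc(Cl)c(Cl)c3)c(SC(C)C)s2)c(C(=O)O)c1-c1ccccc1` differs from compound 3 in one place: phenyl in place of 3-chloro-5-methoxyphenyl on an aromatic carbon.

Going by the values given here, two steps bear on this. The step of a 1.2-fold lower number from compound 2 to compound 3 (0.07 log units; within the scatter) shows that two different substituted six-membered carbon-only rings at this position give numbers within the scatter of each other. The steps of a 24-fold lower number from compound 1 to compound 2 (1.39 log units; beyond the scatter) and a 29-fold lower number from compound 1 to compound 3 (1.46 log units; beyond the scatter) show that the large movement in this series comes from exchanging the nitrogen-containing ring of compound 1 for a carbon-only ring. Compound 4 keeps a carbon-only ring; the step is therefore expected to stay within the scatter, if anything a somewhat higher number, as a 1.6-fold higher number from compound 3 to compound 4 (0.20 log units; within the scatter). Compound 4 is estimated at 1200 nM, in the range 500 nM to 3000 nM.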

Compound 4, half-maximal effective concentration: 3000 nM
The estimate for compound 4 lay 2.5-fold (0.40 log units) below the measured number; the range from low to high includes it.
By their numbers in this assay, from the lowest: compounds 3 and 2 (each within the scatter of the next); then compound 4; then compound 1.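

In this assay the carbon-only rings at this position are no longer equivalent, since removing the substituents from the phenyl ring gives a 3.9-fold higher number from compound 3 to compound 4 (0.60 log units; beyond the scatter) and removing the fluoro alone gives a 3.3-fold higher number from compound 2 to compound 4 (0.52 log units; beyond the scatter) as well. Exchanging pyrimidin-5-yl for plain phenyl gives only a 7.3-fold lower number from compound 1 to compound 4 (0.87 log units; beyond the scatter) and so recovers part of the larger movement seen with the substituted rings of compound 2 and compound 3, which means both the ring atoms and the ring substituents count here, though only these four compounds support that reading. Nothing at hand gives a measured reason for either effect.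

Open, going by these compounds, is whether the chloro or the methoxy of 3-chloro-5-methoxyphenyl alone would match the two together. Also open, on these data alone, is whether an amine on the phenyl ring would track the substituted rings or pyrimidin-5-yl.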